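This account rests on a few compounds, and the source may have more. Where it says the series, first, only, none or still open, it means among the compounds named here.

Of the compounds shown here, three that share one core have been tested in an assay on isolated protein for inhibition of coagulation factor X (Oryctolagus cuniculus), tested at 1 uM; on this read-out higher numbers stand for more inhibition at the one concentration tested (going by the name of the read-out) and lower numbers for less inhibition. Compound 1 `O=C1[C@@H](NS(=O)(=O)c2nc3cc(Cl)ccc3[nH]2)CCN1Cc1cc2c[nH]ccc-2n1` gives 31% in this assay. Compound 2 `Cc1c(S(=O)(=O)N[C@H]2CCN(Cc3cc4c[nH]ccc-4n3)C2=O)sc2ccc(Cl)cc12` gives 37%, and compound 3 `O=C1[C@@H](NS(=O)(=O)c2nc3cc(Cl)ccc3[nH]2)CCN1Cc1cc2[nH]cccc-2n1` gives 14%. Compound 1 stands second highest of the three: its number and that of compound 2 lie within the scatter of each other, while the step of a number 17 percentage points lower from compound 1 to compound 3 (beyond the scatter) shows a modest loss. That step swaps the group on a saturated chain carbon bound to an amide-type nitrogen in a ring, a different part of the molecule from the one changed next.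

Compound 4 `O=C1[C@@H](NS(=O)(=O)c2cc3ncccc3s2)CCN1Cc1cc2c[nH]ccc-2n1` has not yet been measured. It differs from compound 1 on the sulfonyl sulfur: a group of 9 heavy atoms (7 carbon, 1 nitrogen, 1 sulfur; one five-membered aromatic ring with 1 hetero atom, one six-membered aromatic ring with 1 hetero atom) in place of a group of 10 heavy atoms (7 carbon, 2 nitrogen, 1 chlorine; one five-membered aromatic ring with 2 hetero atoms, one six-membered aromatic ring of carbon only), on a sulfonyl sulfur The chlorine and the single hydrogen-bond donor of the leaving group are gone. Within the data shown here, no measured step changes this position, so the only guide is that compound 1 and compound 2, which also differ on the sulfonyl sulfur, sit within the scatter of each other. The expected step is therefore small, a number 6 percentage points lower from compound 1 to compound 4 (within the scatter), leaning slightly downward because compound 1 gives 31% while its donor is lost. Compound 4 is estimated at 25%, with a range from 10% to 45%.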

Compound 4, a percentage reported as inhibition, at one concentration (the size of the read-out at that concentration, not a potency): 61%
The estimate for compound 4 lay 36 percentage points below the measured number, outside the stated range (above it).
By their numbers in this assay, from the lowest: compound 3; then compounds 1 and 2 (each within the scatter of the next); then compound 4.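

The group on the sulfonyl sulfur clearly matters in this assay: swapping out 5-chloro-1H-benzimidazol-2-yl gives a number 30 percentage points higher from compound 1 to compound 4 (beyond the scatter), an upward move at this position, whereas the earlier change on the saturated chain carbon gave a number 17 percentage points lower from compound 1 to compound 3 (beyond the scatter). Until now the only hint about the sulfonyl sulfur was compound 2, which carries another group there and gives 37%, within the scatter of compound 1, so this position could have looked rather insensitive. The entering group has no chlorine and no hydrogen-bond donor, so neither feature is needed on this group for compound 4 to reach its higher number, though no measurement at hand says why the number rises.

The swap changes the chlorine, the donor and the ring atoms all at once, so the compounds shown cannot separate their contributions; a plain 1H-benzimidazol-2-yl group without the chlorine, or a simple phenyl group, on the sulfonyl sulfur would help to pull them apart. Going by these compounds, it also stays open whether the higher number would hold with the group of compound 3 on the saturated chain carbon, and each of these figures is a reading at one concentration rather than a potency.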